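Aryl for Propyl on the Amide Nitrogen of a Sulfonamide

The compounds below may be only part of what the source reports. "The series", "measured", "known", "first", "only" and "open" are said of these compounds alone.

In a functional assay on SH-SY5Y cells (Homo sapiens), read by MTT assay, with a stated time of 24 h (a higher number here means that more compound is needed for the effect, a lower number that less compound is needed), the measured compounds stand as follows:
compound 1 `CCCNC(=O)CN(c1cc(Cl)ccc1OC)S(=O)(=O)c1ccccc1`: > 20000 nM
compound 2 `COc1ccc(CNC(=O)CN(c2cc(Cl)ccc2OC)S(=O)(=O)c2ccccc2)cc1`: > 20000 nM
compound 3 `COc1ccc(Cl)cc1N(CC(=O)Nc1ccc(Cl)cc1)S(=O)(=O)c1ccccc1`: > 20000 nM

Compound 1 gives only a limit in this assay, not a number. The same holds for compound 2, whose value is a limit. Compound 3 likewise reaches only a limit. All three therefore sit together at the limit of > 20000 nM in this assay, at which 3 of the 3 values shown sit, and the steps between them cannot be sized: a step that the two limits leave unreadable from compound 1 to compound 2, a step that the two limits leave unreadable from compound 1 to compound 3 and a step that the two limits leave unreadable from compound 2 to compound 3 are each unreadable from the two limits.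

Compound 4 `COc1ccccc1NC(=O)CN(c1cc(Cl)ccc1OC)S(=O)(=O)c1ccccc1` differs from compound 1 by 2-methoxyphenyl in place of propyl on an amide-type nitrogen. The closest measured comparison is the step from compound 1 to compound 3, where a 4-chlorophenyl also replaces propyl on the amide-type nitrogen; that step left both ends at the limit. Compound 2, with 4-methoxybenzyl in that region, gives no further guidance beyond its limit. With every measured compound at the limit, there is no basis to expect compound 4 to move away from it. Compound 4 is therefore estimated at 30000 nM, with a range from 8000 nM to 100000 nM. The step that the limit leaves unreadable from compound 1 to compound 4 is expected to stay within the scatter.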

Compound 4, half-maximal effective concentration: 15500 nM
For compound 4 the middle estimate is 1.9-fold (0.29 log units) above the measured one; low and high end bracket the measured number.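

For the compounds shown here, compound 4 is the first compound to give a number in this assay, at 15500 nM, so with 2-methoxyphenyl on the amide-type nitrogen the value falls within the range of the assay. The other compounds remain at a limit: the limit of > 20000 nM in this assay, at which 3 of the 4 values shown sit. The readings are an at least 1.2-fold lower number from compound 1 to compound 4 (0.11 log units; that floor lies within the scatter), an at least 1.2-fold lower number from compound 3 to compound 4 (0.11 log units; that floor lies within the scatter) and an at least 1.2-fold lower number from compound 2 to compound 4 (0.11 log units; that floor lies within the scatter); each is only a floor, so the real size of these steps stays unknown and none is shown to exceed the scatter. Compound 3 also carries a six-membered aromatic ring of carbon only on this nitrogen and gives only a limit, so such a ring alone does not yield a number here, although the floor does not firmly separate compound 3 from compound 4.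

Going by these compounds, the steps among compound 1, compound 2 and compound 3 cannot be read, and how far each lies past its limit remains open. Also open, on these data alone, is whether the methoxy group of compound 4 is needed, or whether a plain phenyl or a cyclohexyl group on the amide-type nitrogen would also give a number.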